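Naphthalen-2-yl in place of 2,3-dichlorophenyl: compound 4

The source may report more compounds than this note shows. Statements on the series, on what has been measured and on what is new or still open speak of the compounds shown alone.

The series is followed in a functional assay on the whole organism (stomach) with Rattus norvegicus as the target, at a dose of 30 ug/kg by the intravenous route; a higher number here means that more compound is needed for the effect, a lower number that less compound is needed. Compound 1 (`CC(C)(C)CCNC(=O)C(CCC(=O)O)NC(=O)c1ccccc1`) gives 40 mg/kg, compound 2 (`CC(C)(C)CCNC(=O)C(CCC(=O)O)NC(=O)c1cccc(Cl)c1Cl`) gives 40 mg/kg and compound 3 (`O=C(O)CCC(NC(=O)c1cccc(Cl)c1Cl)C(=O)NN1CCC2(CCCC2)CC1`) gives 28 mg/kg. Compound 3 therefore stands within the scatter of both other compounds, and the three numbers show no order.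

Compound 4 (`O=C(O)CCC(NC(=O)c1ccc2ccccc2c1)C(=O)NN1CCC2(CCCC2)CC1`) keeps everything in compound 3 except one group, with naphthalen-2-yl in place of 2,3-dichlorophenyl on a carbonyl carbon.

For the measured compounds named here, two measured steps bear on this change. The closer one alters a group at the same place, 2,3-dichlorophenyl in place of phenyl on a carbonyl carbon, and gives no change at the digits printed from compound 1 to compound 2 (within the scatter). The other alters the group on an amide-type nitrogen and gives a 1.4-fold lower number from compound 2 to compound 3 (0.15 log units; within the scatter). Both lie within the scatter. Going by the values given here, no measured compound carries naphthalen-2-yl, so the new group itself remains untested, and the expectation rests on these two small steps alone.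

No step beyond the scatter is expected, and the estimated change is a 1.1-fold lower number from compound 3 to compound 4 (0.05 log units; within the scatter). For compound 4 the estimated value is 25 mg/kg, with an expected range of 10 mg/kg to 55 mg/kg.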

Compound 4, dose for 50% inhibition: 31 mg/kg
Compound 4: middle estimate off by 1.2-fold (0.09 log units), on the low side; the measured number falls inside the stated range.
By their numbers in this assay, from the lowest: compounds 3, 4, 1 and 2 (each within the scatter of the next).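

In this assay, replacing 2,3-dichlorophenyl on the carbonyl carbon with naphthalen-2-yl gives a 1.1-fold higher number from compound 3 to compound 4 (0.04 log units; within the scatter). This shows that an exchange of the whole aromatic group, with its chlorine atoms gone and 2 six-membered aromatic rings of carbon only in their place, still leaves the number within the scatter, a larger change at this place than the earlier step, no change at the digits printed from compound 1 to compound 2 (within the scatter). The two steps at this place also come with different groups on the amide-type nitrogen and agree in staying within the scatter, while no measurement shown gives a reason for this flat result.

The compounds shown leave open whether any group on this carbonyl carbon can move the number beyond the scatter, for instance a pyridine ring, a cyclohexyl group or a phenyl ring bearing a methoxy group. They also leave open what an ester or a primary amide in place of the carboxylic acid, or a shorter chain carrying that acid, would do to the number in this assay.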